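Swapping pyridyl for chlorophenyl in a chromone series

A few compounds are considered here, and "the series" means these few. Any claim that something is new, unique, unknown or untested is made for them only; others in the source may bear on it.

Compound 2 `COc1cc(OC)c2c(=O)cc(/C=C/c3ccncc3)oc2c1` was tested in a functional assay on SKHep cells (Homo sapiens) for antiproliferative activity, read by MTT assay, with a stated time of 12 h; a lower number here means a stronger inhibitor, a higher number a weaker inhibitor. In this assay compound 2 gave > 40000 nM, which is a limit of the assay rather than a number. Compound 1 `COc1ccc2oc(/C=C/c3ccc(OC(F)(F)F)cc3)cc(=O)c2c1` likewise stopped at > 40000 nM, again a limit. Compound 3 `COc1cccc2oc(/C=C/c3ccc(OC(F)(F)F)cc3)cc(=O)c12` gives 21000 nM in this assay. Two of the three values shown sit at the limit of > 40000 nM in this assay, at which 2 of the 3 values shown sit, so compound 2 stands at the edge of what this assay can report. Compound 4 `COc1cc(OC)c2c(=O)cc(/C=C/c3ccc(Cl)cc3)oc2c1` differs from compound 2 by 4-chlorophenyl in place of pyridin-4-yl on a double-bonded chain carbon bound to a double-bonded chain carbon. Within the data shown here, no comparable step has been measured, so the direction of the change is open, and compound 4 is expected to stay near the weak end. The expected change is an at least 1.3-fold lower number from compound 2 to compound 4 (0.12 log units; that floor lies within the scatter). Compound 4 is estimated to give 30000 nM, within 8000 nM to 80000 nM.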

Compound 4, half-maximal inhibitory concentration: 26900 nM
Beside the measured number, compound 4's estimate is 1.1-fold (0.05 log units) above it; the measured number falls inside the stated range.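

With 4-chlorophenyl in place of pyridin-4-yl on a double-bonded chain carbon bound to a double-bonded chain carbon, this assay shows an at least 1.4-fold lower number from compound 2 to compound 4 (0.17 log units; that floor lies within the scatter). Among these compounds, this is the first step that can be read at this place, and it gives only a floor. Compound 2 carries a limit rather than a number, so the size of the step stays unfixed: the limit of > 40000 nM in this assay, at which 2 of the 4 values shown sit.

The compounds shown leave open how large the step truly is, and what an amine or a carboxylic acid would give in that same place.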